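A few compounds are considered here, and "the series" means these few. Any claim that something is new, unique, unknown or untested is made for them only; others in the source may bear on it.

Measured compounds:
- compound 1, `Cc1c(C(C)C)c(=O)on1C(=O)N1CCCCC1`: 2 nM
- compound 2, `Cc1c(CC(C)C)c(=O)on1C(=O)N1CCCCC1`: 5 nM
- compound 3, `Cc1c(C(C)C)c(=O)on1C(=O)N1CCCC(CO)C1`: 180 nM

Compound 1 stands at the lowest number of the three in an assay (strain Wistar) for inhibition of Hormone-sensitive lipase (Rattus norvegicus), read by spectrophotometry; a lower number here means a stronger inhibitor, a higher number a weaker inhibitor. Its nearest neighbour is compound 2, a 2.5-fold higher number from compound 1 to compound 2 (0.40 log units; beyond the scatter), and its furthest is compound 3, a 90-fold higher number from compound 1 to compound 3 (1.95 log units; beyond the scatter).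

Compound 4, `Cc1c(C(C)C)c(=O)on1C(=O)N1CCC(c2cccc(F)c2)CC1`, keeps the core of compound 1 and changes one spot: 3-fluorophenyl in place of hydrogen on a saturated ring carbon. Among the measured compounds shown here, no measured step adds an aromatic ring in this position, so the only step that bears on it is the one to compound 3, which also placed a new group on a saturated ring carbon of the six-membered ring with one nitrogen; there the number rose sharply, a 90-fold higher number from compound 1 to compound 3 (1.95 log units; beyond the scatter). The 3-fluorophenyl group differs from hydroxymethyl in size and in carrying no hydrogen-bond donors or acceptors, so the loss is not expected to be as large, but a rise beyond the scatter is expected: compound 4 is estimated to sit at a 15-fold higher number from compound 1 to compound 4 (1.18 log units; beyond the scatter). Compound 4 is therefore expected at about 30 nM in this assay, within a range of 5 nM to 200 nM.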

Compound 4, half-maximal inhibitory concentration: 12 nM
Compound 4: middle estimate off by 2.5-fold (0.40 log units), on the high side, and the stated range covers the measured number.
By their numbers in this assay, from the lowest: compound 1; then compound 2; then compound 4; then compound 3.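

In this assay, the saturated ring carbon three ring bonds from the ring nitrogen tolerates a large group at a moderate cost: placing 3-fluorophenyl there gives a 6.0-fold higher number from compound 1 to compound 4 (0.78 log units; beyond the scatter) in a modest step. Even with this group of 7 heavy atoms, compound 4 reads 12 nM and remains a strong inhibitor, so a large addition to this ring need not cost as much as the step to compound 3 did. Nothing given here explains the size of this step.

The compounds shown leave open how a plain phenyl, an amine or a carboxylic acid on the same carbon would compare, and so what the fluorine contributes. They also cannot separate the effect of hydroxymethyl in compound 3 from that of its different ring carbon.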